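Swapping the Furan-2-yl Ring for 4-Hydroxyphenyl

This account rests on a few compounds, and the source may have more. Where it says the series, first, only, none or still open, it means among the compounds named here.

Compound 2 `CC1(C)C=C(n2ccccc2=O)c2cc(C(=O)c3ccco3)ccc2O1` is the more potent of the two compounds measured in a functional assay (aorta) with Rattus norvegicus as the target; a higher number here means a more potent compound, by a factor of ten per unit of this negative logarithm, a lower number a less potent compound. In this assay compound 2 gives 6.49, the highest of the two numbers. Its nearest neighbour is compound 1 `CC1(C)C=C(n2ccccc2=O)c2ccccc2O1`, which carries hydrogen where compound 2 carries the (furan-2-yl)carbonyl group; in this assay compound 1 gives 5.43. Among the measured compounds shown here, the single step joining them, a number 1.06 log units higher from compound 1 to compound 2 (beyond the scatter), lies well beyond the scatter.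

Compound 3 `CC1(C)C=C(n2ccccc2=O)c2cc(C(=O)c3ccc(O)cc3)ccc2O1` keeps that carbonyl and changes only the ring attached to it: 4-hydroxyphenyl in place of furan-2-yl on a carbonyl carbon. For the measured compounds named here, no measured step compares one aryl group on this carbonyl carbon with another. Going by the values given here, the only step available, a number 1.06 log units higher from compound 1 to compound 2 (beyond the scatter), concerns the whole (furan-2-yl)carbonyl group against hydrogen and says nothing about furan-2-yl against 4-hydroxyphenyl. Because compound 2 already holds the carbonyl that gave a number 1.06 log units higher from compound 1 to compound 2 (beyond the scatter), and compound 3 retains it, no step beyond the scatter is expected. Compound 3 is therefore estimated at 6.4, within 5.7 to 7.1. The implied step, a number 0.09 log units lower from compound 2 to compound 3 (within the scatter), is expected to stay within the scatter.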

Compound 3, logarithm of the reciprocal of the active concentration, log(1/C): 6.65
Beside the measured number, compound 3's estimate is 0.25 log units below it; the measured number falls inside the stated range.
By their numbers in this assay, from the lowest: compound 1; then compounds 2 and 3 (each within the scatter of the next).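

Among the compounds shown here, the first comparison of two rings on this carbonyl carbon, in this assay, gives a number 0.16 log units higher from compound 2 to compound 3 (within the scatter) and so does not separate 4-hydroxyphenyl from furan-2-yl. The large gain over hydrogen is therefore not tied to furan-2-yl alone, since the second ring also gives a number 1.22 log units higher from compound 1 to compound 3 (beyond the scatter) and both aryl carbonyl groups stand clear of compound 1. The hydrogen-bond donor that enters with 4-hydroxyphenyl, which furan-2-yl lacks, and the change from a five-membered to a six-membered aromatic ring together bring no step beyond the scatter.

The compounds shown leave open whether the gain needs an aromatic ring on the carbonyl carbon at all, as both groups that carry it have one, so that a methyl group or a longer chain there remains an untested case. They also leave open whether the hydroxyl of compound 3 contributes anything, which a methoxy group or an amine in its stead would address, and no measurement at hand accounts for the behaviour of either group.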